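This account rests on a few compounds, and the source may have more. Where it says the series, first, only, none or still open, it means among the compounds named here.

Compound 1 `COc1cc2nc(O)nc(C)c2cc1OC`: 2.42 mg/kg
Compound 2 `CCc1nc(O)nc2cc(OC)c(OC)cc12`: 3.4 mg/kg

Among the compounds with values here, both values come from a functional assay on the whole organism (Myocardium) with Canis familiaris (Canis lupus familiaris) as the target, at a dose of 8.75 mg/kg by the intravenous route (on this read-out lower numbers stand for an effect already at smaller amounts and higher numbers for an effect only at larger amounts of compound), and compound 2 lies within the scatter of compound 1, its only neighbour. Compound 3 `COc1cc2nc(O)nc(C(C)C)c2cc1OC` differs from compound 2 by methyl in place of hydrogen on a saturated chain carbon bound to an aromatic carbon and a saturated chain carbon, which turns ethyl to isopropyl. The nearest measured change, methyl in place of hydrogen on a saturated chain carbon bound to an aromatic carbon, gave a 1.4-fold higher number from compound 1 to compound 2 (0.15 log units; within the scatter), so no step beyond the scatter is expected for compound 3 in this assay. The expected change is a 1.2-fold higher number from compound 2 to compound 3 (0.07 log units; within the scatter). Compound 3 is estimated at 4 mg/kg, with an expected range from 1.8 mg/kg to 9 mg/kg.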

Compound 3, dose for half-maximal effect: 1.39 mg/kg
Estimate against measurement, compound 3: 2.9-fold (0.46 log units) above, outside the stated range (below it).
By their numbers in this assay, from the lowest: compounds 3, 1 and 2 (each within the scatter of the next, the first and the last beyond it).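

In this assay, within the data shown here, the change from ethyl to isopropyl gave a 2.4-fold lower number from compound 2 to compound 3 (0.39 log units; beyond the scatter) and so produced the first step at this position that lies beyond the scatter, while the methyl in place of hydrogen one carbon closer to the aromatic carbon had stayed within it. Replacing methyl directly with isopropyl gave a 1.7-fold lower number from compound 1 to compound 3 (0.24 log units; within the scatter) and stayed within the scatter. Nothing available here explains the step from ethyl to isopropyl.

The compounds shown leave open whether a longer chain such as butyl or a tert-butyl group would continue this step. They also leave open what an amine on this carbon would do.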